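A new carbamoyl group in place of compound 2's side chain

The source may hold more compounds than are shown below. What is called first, only, known or untested is meant among the compounds shown, and "the series" means these compounds.

Measured so far in a functional assay on KB cells (Homo sapiens) for antiproliferative activity, read by sulforhodamine B assay, with a stated time of 3 days; on this read-out lower numbers stand for stronger inhibition of growth and higher numbers for weaker inhibition of growth:
- compound 1 `O=C(c1cccc(Nc2ncc(F)c(Nc3ccc(F)cc3)n2)c1)N1CCCCC1`: 14800 nM
- compound 2 `COCC(=O)Nc1cccc(Nc2ncc(F)c(Nc3ccc(F)cc3)n2)c1`: 6250 nM

Compound 2 holds the lower of these two numbers, and the gap to compound 1 lies beyond the scatter. The next compound to be measured is compound 3 `Cn1ccnc1NC(=O)c1cccc(Nc2ncc(F)c(Nc3ccc(F)cc3)n2)c1`, which differs from compound 2 at one place: (1-methyl-1H-imidazol-2-yl)carbamoyl in place of ((methoxymethyl)carbonyl)amino on an aromatic carbon. In words, (1-methyl-1H-imidazol-2-yl)carbamoyl stands in place of ((methoxymethyl)carbonyl)amino on an aromatic carbon.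

For the measured compounds named here, only one measured step bears on this change: a 2.4-fold lower number from compound 1 to compound 2 (0.37 log units; beyond the scatter), which is modest and involves a group on an aromatic carbon. Compound 3, like compound 1, has its carbonyl bonded to the aromatic carbon, so a small move toward the higher number is expected in this assay, though two compounds offer thin support. The expected step is small: a 1.3-fold higher number from compound 2 to compound 3 (0.11 log units; within the scatter), and this is only an estimate. Compound 3 is estimated at 8000 nM, with an expected range from 2500 nM to 22000 nM.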

Compound 3, concentration for 50% growth inhibition: 14600 nM
Beside the measured number, compound 3's estimate is 1.8-fold (0.26 log units) below it, and the stated range covers the measured number.
By their numbers in this assay, from the lowest: compound 2; then compounds 3 and 1 (each within the scatter of the next).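

In this assay, the step of a 2.3-fold higher number from compound 2 to compound 3 (0.37 log units; beyond the scatter) shows that this aromatic carbon, meta to a large group, does not tolerate every amide side chain equally: (1-methyl-1H-imidazol-2-yl)carbamoyl does not keep the lower number seen with ((methoxymethyl)carbonyl)amino. The second comparison adds something the first two compounds could not show, as the step of a 1.0-fold lower number from compound 1 to compound 3 (0.01 log units; within the scatter) places two different groups on the carbonyl carbon, (1-methyl-1H-imidazol-2-yl)amino and piperidin-1-yl, within the scatter of each other, so on these two compounds the five-membered aromatic ring brings no measurable gain over the piperidine. Nothing available here accounts for either step.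

Compound 2 is the only one of the three with nitrogen rather than carbonyl on the aromatic carbon, so the compounds shown cannot separate the direction of the amide from the rest of the side chain. From the compounds shown here alone, it also remains open whether a carboxylic acid on this aromatic carbon, or a morpholine or a dimethylamino group on the carbonyl carbon, would read with compound 2 or with the other two.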